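The source may hold more compounds than are shown below. What is called first, only, known or untested is meant among the compounds shown, and "the series" means these compounds.

Compound 2, with structure `COC(=O)/C=C/c1cccc(N(Cc2ccc(-c3ccc(F)c(Cl)c3)cc2)C(=O)C2CCCCC2)c1`, shows the lowest value among three measured compounds in an assay on isolated protein with Bile acid receptor (Homo sapiens) as the target (on this read-out lower numbers stand for an effect already at smaller amounts and higher numbers for an effect only at larger amounts of compound), where compound 2 gives 66 nM. Its nearest companion is compound 1, of structure `COC(=O)/C=C/c1cccc(N(Cc2ccc(/C=C/c3c(C)cc(C)cc3C)cc2)C(=O)C(C)C)c1`, which in this assay gives 149 nM, a step beyond the scatter. Furthest is compound 3, of structure `COC(=O)/C=C/c1cccc(N(Cc2ccc(/C=C/C(=O)OC(C)(C)C)cc2)C(=O)c2ccco2)c1`, which in this assay gives 205 nM. The unmeasured compound 4, with structure `COC/C=C/c1ccc(CN(C(=O)C2CCCCC2)c2cccc(/C=C/C(=O)OC)c2)cc1`, differs from compound 2 in one place: 3-methoxyprop-1-en-1-yl in place of 3-chloro-4-fluorophenyl on an aromatic carbon. For the measured compounds named here, no step between measured compounds is directly comparable, but compound 1 and compound 3, each carrying a chain with a double bond outside aromatic rings in place of a ring at this position, both sit weaker than compound 2. On that basis the step is expected to run toward a higher number, beyond the scatter, and the expected step is a 4.5-fold higher number from compound 2 to compound 4 (0.66 log units; beyond the scatter). Compound 4 is therefore estimated to give about 300 nM in this assay, with a likely range from 110 nM to 900 nM.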

Compound 4, half-maximal effective concentration: 233 nM
For compound 4 the middle estimate is 1.3-fold (0.11 log units) above the measured one; low and high end bracket the measured number.
By their numbers in this assay, from the lowest: compound 2; then compounds 1, 3 and 4 (each within the scatter of the next).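

For the compounds shown here, this is the first one-place comparison at this position: with the rest of compound 2 held constant, the change gives a 3.5-fold higher number from compound 2 to compound 4 (0.55 log units; beyond the scatter) in this assay. The earlier compounds shown here differed from compound 2 in more than one place, so they could not isolate this substitution. The swap removes the aromatic ring together with its chlorine and fluorine and adds a chain with one double bond and one hydrogen-bond acceptor, yet compound 4 still gives 233 nM; nothing available accounts for the step.

This single step cannot separate the loss of the ring from the loss of the halogens or the gain of the ether oxygen. A plain phenyl ring, or a carboxylic acid at the end of the chain, could help to separate them, but the compounds shown leave both open.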